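The source may report more compounds than this note shows. Statements on the series, on what has been measured and on what is new or still open speak of the compounds shown alone.

Of the compounds shown here, two that share a core have been measured so far. Compound 1 `CC(=O)OCc1ccc2oc(=O)c(C(=O)Oc3cccc(Cl)c3)cc2c1` gives 6.17% in a functional assay on HT-1080 cells (Homo sapiens), read by transwell migration, with a stated time of 24 h, tested at 10 uM; a lower number here means a stronger effect, a higher number a weaker effect of the compound at the concentration tested. Compound 2 `CCC(=O)OCc1ccc2oc(=O)c(C(=O)Oc3cccc(Br)c3)cc2c1` gives 21.3% in this assay, the higher of the two numbers, with compound 1 standing lower by a margin beyond the usual scatter. Compound 3 `CCCCCC(=O)OCc1ccc2oc(=O)c(C(=O)Oc3cccc(Br)c3)cc2c1` differs from compound 2 in one place: propyl in place of hydrogen on a saturated chain carbon, two bonds along the chain from a carbonyl carbon. Going by the values given here, no measured pair shows what this change does, so the expectation leans on the nearest measured compound. The step of a number 3.7 percentage points higher from compound 2 to compound 3 (within the scatter) is expected to be small, within the scatter or slightly toward a weaker effect. Compound 3 is therefore expected to give 25%, with a range from 8% to 45%.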

Compound 3, a percentage reported as activity, at one concentration (the size of the read-out at that concentration, not a potency): 33.9%
Estimate against measurement, compound 3: 8.9 percentage points below; measured number inside the range.
By their numbers in this assay, from the lowest: compound 1; then compound 2; then compound 3.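

Going by these compounds alone, with propyl in place of hydrogen on a saturated chain carbon, two bonds along the chain from a carbonyl carbon, this assay gives the first readable step at this position: a number 12.6 percentage points higher from compound 2 to compound 3 (beyond the scatter). Going from propanoyl to pentylcarbonyl therefore weakens the effect at the concentration tested, showing that the ester chain is not indifferent to this change. Nothing at hand gives a reason for this step. On these data alone, whether the effect weakens steadily with chain length remains open. A butanoyl group, a longer chain or an amine at the chain end could test this.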